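A few compounds are considered here, and "the series" means these few. Any claim that something is new, unique, unknown or untested is made for them only; others in the source may bear on it.

Measured compounds:
compound 1 `Cc1nc2c3ccccc3ccc2c2nc3c(ccc4ccccc43)c(-c3cccc([N+](=O)[O-])c3)c12` gives 54.2 ug/mL
compound 2 `Cc1nc2c3ccccc3ccc2c2nc3c(ccc4ccccc43)c(-c3cccnc3)c12` gives 63.6 ug/mL
compound 3 `Cc1nc2c3ccccc3ccc2c2nc3c(ccc4ccccc43)c(-c3ccccc3Cl)c12` gives 74.6 ug/mL

The three compounds share one core and differ only in the aryl group on its aromatic carbon. In a functional assay, read by spectrophotometry, with a stated time of 15 min (a lower number here means a stronger inhibitor, a higher number a weaker inhibitor), compound 1 gives the lowest of the three numbers, but neither of its companions is separated from it by a meaningful margin: a 1.2-fold higher number from compound 1 to compound 2 (0.07 log units; within the scatter) and a 1.4-fold higher number from compound 1 to compound 3 (0.14 log units; within the scatter) both sit inside the scatter, as does a 1.2-fold higher number from compound 2 to compound 3 (0.07 log units; within the scatter).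

Compound 4 `Cc1nc2c3ccccc3ccc2c2nc3c(ccc4ccccc43)c(-c3ccc(O)cc3)c12` has not yet been measured. It differs from compound 1 as follows: 4-hydroxyphenyl in place of 3-nitrophenyl on an aromatic carbon.

Among the compounds with values here, none of the measured steps introduces 4-hydroxyphenyl, so they bear on the new compound only in a general way: each swap of the aryl group at this position, whether to pyridin-3-yl or to 2-chlorophenyl, left this assay essentially unchanged. On that basis a step beyond the scatter is not expected in either direction for compound 4.

Compound 4 is therefore estimated to give about 62 ug/mL in this assay, within a range of 30 ug/mL to 125 ug/mL. This estimate corresponds to a step of a 1.1-fold higher number from compound 1 to compound 4 (0.06 log units; within the scatter), which is expected to stay within the usual scatter.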

Compound 4, half-maximal inhibitory concentration: 44.1 ug/mL
For compound 4 the middle estimate is 1.4-fold (0.15 log units) above the measured one, and the stated range covers the measured number.
By their numbers in this assay, from the lowest: compounds 4, 1, 2 and 3 (each within the scatter of the next).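

In this assay, 4-hydroxyphenyl brings a hydrogen-bond donor to this aromatic carbon, opposite the ring nitrogen, where the earlier aryl groups have none. Even so, the three new steps stay within the scatter: a 1.2-fold lower number from compound 1 to compound 4 (0.09 log units; within the scatter) and a 1.4-fold lower number from compound 2 to compound 4 (0.16 log units; within the scatter) and a 1.7-fold lower number from compound 3 to compound 4 (0.23 log units; within the scatter). The earlier compounds shown here showed this only for 3-nitrophenyl, pyridin-3-yl and 2-chlorophenyl, and compound 4 adds a hydroxyl-bearing ring to the aryl groups that cannot be told apart here. No measurement is available that would explain these results.

The compounds shown leave open whether any group at this carbon can move the number beyond the scatter, for example a carboxylic acid or an amine on the phenyl ring, or a saturated chain in place of the ring. They also leave open how far the methyl group on the shared core matters.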